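The source may report more compounds than this note shows. Statements on the series, on what has been measured and on what is new or still open speak of the compounds shown alone.

Three compounds share one core, and their results in an assay on mitochondria (strain Sprague-Dawley) for inhibition of Amine oxidase [flavin-containing] B (Rattus norvegicus), read by fluorescence and Amplex Red, with stated times of 30 min and 45 min (on this read-out higher numbers stand for weaker inhibition and lower numbers for stronger inhibition), differ. Compound 1, `COc1cccc(/C=C/C(=O)Nc2nc3ccccc3c(=O)s2)c1`, gives 281 nM. Compound 3, `COc1cccc(/C=C/CC(=O)Nc2nc3ccccc3c(=O)s2)c1`, gives 2020 nM. Compound 2, `O=C(CCCc1ccc(Cl)c(Cl)c1)Nc1nc2ccccc2c(=O)s1`, gives 3300 nM. Compound 2 thus gives a higher number than compound 1, a gap that lies beyond the usual scatter of such measurements, whereas the number for compound 3 lies within the scatter of that for compound 2, so those two cannot be told apart.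

Compound 4, `O=C(CCCc1cccc(Cl)c1)Nc1nc2ccccc2c(=O)s1`, is the next compound. Its structure differs from compound 2 in a single spot: hydrogen in place of chloro on an aromatic carbon, ortho to a chloro group and para to a large group. Among the compounds with values here, no two measured compounds differ in exactly this way, so there is no measured step to lean on. The expected change from compound 2 to compound 4 in this assay is a small shift toward a higher number, most likely not beyond the scatter, a 1.5-fold higher number from compound 2 to compound 4 (0.18 log units; within the scatter). Compound 4 is therefore expected to give about 5000 nM, within a range from 2000 nM to 15000 nM.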

Compound 4, half-maximal inhibitory concentration: 6880 nM
The estimate for compound 4 lay 1.4-fold (0.14 log units) below the measured number, within the range that was stated.
By their numbers in this assay, from the lowest: compound 1; then compounds 3 and 2 (each within the scatter of the next); then compound 4.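

Within the data shown here, the change from 3,4-dichlorophenyl to 3-chlorophenyl is the first single-spot comparison in this set, and in this assay it gives a 2.1-fold higher number from compound 2 to compound 4 (0.32 log units; beyond the scatter). With the chain and the shared core unchanged, this spot on the aromatic ring is therefore not indifferent: the chloro goes with stronger inhibition than hydrogen does, though the effect is modest. Nothing available explains why this chloro matters.

Going by these compounds, it remains open whether a fluoro, methyl or methoxy group at this spot would match the chloro, and what replacing the remaining chloro of compound 4 with hydrogen would do. It is also unknown whether the same step would hold on a shorter chain or on the chains of compound 1 and compound 3.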